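Fluoro for trifluoromethyl: estimating compound 4

The source may report more compounds than this note shows. Statements on the series, on what has been measured and on what is new or still open speak of the compounds shown alone.

Measured so far:
compound 1 `O=C1O/C(=C\Cn2cc(C(F)(F)F)c(=O)[nH]c2=O)C(OCc2ccccc2)=C1OCc1ccccc1` gives 2000 nM
compound 2 `O=C1O/C(=C\Cn2cc(F)c(=O)[nH]c2=O)C(OCc2ccccc2)=C1OCc1ccccc1` gives 5100 nM
compound 3 `O=C1OC(C(O)Cn2cc(C(F)(F)F)c(=O)[nH]c2=O)C(OCc2ccccc2)=C1OCc1ccccc1` gives 50200 nM

All three were run in an ADME assay on L1210/0 cells (Mus musculus) for cytotoxicity, with a stated time of 48 h; a lower number here means a stronger inhibitor, a higher number a weaker inhibitor. From compound 1 to compound 2 the change is fluoro in place of trifluoromethyl on an aromatic carbon, which gave a 2.6-fold higher number from compound 1 to compound 2 (0.41 log units; beyond the scatter). Compound 4 `O=C1OC(C(O)Cn2cc(F)c(=O)[nH]c2=O)C(OCc2ccccc2)=C1OCc1ccccc1` has not been measured; it carries the same change relative to compound 3, namely (fluoro in place of trifluoromethyl on an aromatic carbon), at a place described in identical words. How the core of compound 3 differs from the core of compound 1 is not broken down here; in this assay compound 3 gives a higher number than either compound 1 or compound 2. Among the measured compounds shown here, because the only earlier instance of this change is a 2.6-fold higher number from compound 1 to compound 2 (0.41 log units; beyond the scatter), the step from compound 3 to compound 4 is expected to be of that order, a 2.6-fold higher number from compound 3 to compound 4 (0.41 log units; beyond the scatter). Compound 4 is accordingly estimated at 130000 nM, with a likely range from 50000 nM to 320000 nM.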

Compound 4, half-maximal inhibitory concentration: 140000 nM
The estimate for compound 4 lay 1.1-fold (0.03 log units) below the measured number, and the stated range covers the measured number.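

In this assay, fluoro in place of trifluoromethyl on an aromatic carbon gives a 2.8-fold higher number from compound 3 to compound 4 (0.45 log units; beyond the scatter), and this step agrees with the earlier one on the other core: the same change on two cores in this assay, a 2.6-fold higher number (0.41 log units; beyond the scatter) from compound 1 to compound 2 and a 2.8-fold higher number (0.45 log units; beyond the scatter) from compound 3 to compound 4, 1.1-fold (0.04 log units) apart, within the scatter of two such steps

The change therefore carries over between the core of compound 1 and the core of compound 3 with its direction and size kept. Among the compounds shown here, this rests on only two pairs in a single cell assay, and it does not show that the step would hold on any further core, nor why the number rises.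

The compounds shown leave open whether other groups on this aromatic carbon, such as hydrogen, methyl, chloro or a nitrile, would keep the same order on both cores.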